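The source may hold more compounds than are shown below. What is called first, only, known or untested is meant among the compounds shown, and "the series" means these compounds.

Measured so far:

Compound 1, `CCc1cc(C)n(C)c(=O)c1CN1CCc2c(Cl)cc(-c3c(C)noc3C)c(Cl)c2C1=O`: 82 nM
Compound 2, `Cc1cc(C)n(C)c(=O)c1CN1CCc2c(Cl)cc(-c3c(C)noc3C)c(Cl)c2C1=O`: 14 nM

Both compounds were tested in an assay on isolated protein for inhibition of histone-lysine N-methyltransferase EZH2 (Homo sapiens), read by filter binding, with a stated time of 1 h; on this read-out lower numbers stand for stronger inhibition and higher numbers for weaker inhibition. Within the data shown here, compound 2 holds the lowest number of the two; the only other compound, compound 1, sits higher by the step of a 5.9-fold lower number from compound 1 to compound 2 (0.77 log units; beyond the scatter), which arose from a single change: hydrogen in place of methyl on a saturated chain carbon bound to an aromatic carbon. That is the whole of what has been measured.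

Compound 3, `COc1cc(C)n(C)c(=O)c1CN1CCc2c(Cl)cc(-c3c(C)noc3C)c(Cl)c2C1=O`, has not yet been measured. It differs from compound 2 in one place: methoxy in place of methyl on an aromatic carbon. Among the measured compounds shown here, no measured step touches this position with this kind of group, so the step from compound 1 to compound 2 bears on it only loosely, as a sign that a change of one heavy atom at the edge of the shared core can move the number by a modest, clearly detectable amount. With nothing closer to go on, the expected step of a 1.6-fold higher number from compound 2 to compound 3 (0.20 log units; within the scatter) is small and could fall on either side of the scatter. Compound 3 is therefore estimated at 22 nM, with a range from 6 nM to 80 nM.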

Compound 3, half-maximal inhibitory concentration: 11.6 nM
Compound 3: middle estimate off by 1.9-fold (0.28 log units), on the high side, and the stated range covers the measured number.
By their numbers in this assay, from the lowest: compounds 3 and 2 (each within the scatter of the next); then compound 1.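

In this assay, methoxy in place of methyl on this aromatic carbon gives a 1.2-fold lower number from compound 2 to compound 3 (0.08 log units; within the scatter), so compound 2 and compound 3 cannot be told apart, and a larger group with a hydrogen-bond acceptor, where methyl has none, leaves the number where it was. Set against ethyl at the same carbon, methoxy gives a 7.1-fold lower number from compound 1 to compound 3 (0.85 log units; beyond the scatter), which shows that among these three compounds a group larger than methyl does not by itself bring a higher number: methoxy, with 2 heavy atoms against the 1 of methyl, stays level with methyl, while ethyl stands clearly apart from both. Nothing available explains why ethyl and methoxy part ways at this position.

As far as these compounds go, it remains open whether ethoxy, with its longer chain, would follow methoxy or ethyl, and where a hydroxyl, an amine or a chlorine on this carbon would fall. The single read-out also cannot say whether compound 2 and compound 3, level on the isolated protein, would stay level in cells.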